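Swapping a dichlorophenyl for a trimethylphenyl on the hydrazone arm

The source may report more compounds than this note shows. Statements on the series, on what has been measured and on what is new or still open speak of the compounds shown alone.

Compound 1 `Cc1cccc(/C=N/Nc2ncc3c(n2)n(C2CCCC2)c(=O)c(=O)n3C)c1`: in a functional assay on PC-3 cells (Homo sapiens) for antiproliferative activity, read by MTT assay (a higher number here means a weaker inhibitor, a lower number a stronger inhibitor), compound 1 gives 53600 nM.
Compound 2 `Cn1c(=O)c(=O)n(C2CCCC2)c2nc(N/N=C/c3ccc(O)c(F)c3)ncc21`: in this assay compound 2 gives 85200 nM.
Compound 3 `Cn1c(=O)c(=O)n(C2CCCC2)c2nc(N/N=C/c3cccc(Cl)c3Cl)ncc21`: in this assay compound 3 gives 17200 nM.

Compound 3 stands at the lowest number of the three, and both steps leading to it lie beyond the scatter: a 3.1-fold lower number from compound 1 to compound 3 (0.49 log units; beyond the scatter), and a 5.0-fold lower number from compound 2 to compound 3 (0.69 log units; beyond the scatter). The two weaker compounds are not separated from each other, since a 1.6-fold higher number from compound 1 to compound 2 (0.20 log units; within the scatter).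

Compound 4 `Cc1cc(C)c(/C=N/Nc2ncc3c(n2)n(C2CCCC2)c(=O)c(=O)n3C)c(C)c1` keeps the shared core and changes only the aryl group of the hydrazone: 2,4,6-trimethylphenyl in place of 2,3-dichlorophenyl on a carbon with a double bond to nitrogen. Going by the values given here, the step that bears most directly on this change is the one between compound 1 and compound 3, because a 3.1-fold lower number from compound 1 to compound 3 (0.49 log units; beyond the scatter) describes a methyl-bearing phenyl being exchanged for the dichlorophenyl, and compound 4 moves back toward a methyl-bearing phenyl. Among the compounds with values here, no measured pair shows a trimethylphenyl, so the size is uncertain. A modest rise in the number, roughly undoing that earlier step, is the expectation in this assay.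

Compound 4 is therefore estimated at about 38000 nM, within a range from 12000 nM to 120000 nM. That estimate corresponds to an expected step of a 2.2-fold higher number from compound 3 to compound 4 (0.34 log units; beyond the scatter).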

Compound 4, half-maximal inhibitory concentration: 13900 nM
Estimate against measurement, compound 4: 2.7-fold (0.44 log units) above; measured number inside the range.
By their numbers in this assay, from the lowest: compounds 4 and 3 (each within the scatter of the next); then compounds 1 and 2 (each within the scatter of the next).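

In this assay, putting 2,4,6-trimethylphenyl in place of 2,3-dichlorophenyl gives no change that can be told from the scatter (a 1.2-fold lower number from compound 3 to compound 4 (0.09 log units; within the scatter)), so among these compounds chlorine is not needed to reach the low end of the series: an aryl group of carbon only gets there too. A methyl-bearing phenyl therefore does not by itself mark a higher number, since 2,4,6-trimethylphenyl stands clearly apart from the 3-methylphenyl (a 3.9-fold lower number from compound 1 to compound 4 (0.59 log units; beyond the scatter)) and from the 3-fluoro-4-hydroxyphenyl (a 6.1-fold lower number from compound 2 to compound 4 (0.79 log units; beyond the scatter)). No measurement is available to explain why these aryl groups fall where they do.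

The compounds shown leave open whether the number of methyl groups or their placement on the ring separates compound 4 from compound 1. On these data alone, it also remains open how this position would respond to a phenyl carrying an amine or a carboxylic acid, or to a saturated cyclohexyl ring in place of the aromatic one.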